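Sulfonate esters on HT-29 cells: iodo for isopropyl

A few compounds are considered here, and "the series" means these few. Any claim that something is new, unique, unknown or untested is made for them only; others in the source may bear on it.

Of the compounds shown here, two have numbers so far. Compound 1 `CCC(=O)Nc1ccc(S(=O)(=O)Oc2ccccc2I)cc1` gives 11000 nM in a functional assay on HT-29 cells (Homo sapiens) for antiproliferative activity, read by sulforhodamine B assay, with a stated time of 48 h; on this read-out higher numbers stand for weaker inhibition and lower numbers for stronger inhibition. Compound 2 `CC(C)C(=O)Nc1ccc(S(=O)(=O)Oc2ccccc2C(C)C)cc1` gives 14000 nM in this assay, the highest of the two numbers, with compound 1 the nearest, a gap that lies within the scatter. Among the measured compounds shown here, compound 2 and compound 1 differ in two places at once, so no single step between measured compounds is available.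

The step to compound 3 `CC(C)C(=O)Nc1ccc(S(=O)(=O)Oc2ccccc2I)cc1` changes one place only: iodo in place of isopropyl on an aromatic carbon, on an aromatic carbon of a six-membered aromatic ring of carbon only, ortho to a large group. Compound 1 already carries the iodo group at that place, alongside a different amide, and compound 1 with 11000 nM sits close to compound 2. No step beyond the scatter is therefore expected from compound 2 to compound 3, a step of about a 1.3-fold lower number from compound 2 to compound 3 (0.10 log units; within the scatter). Compound 3 is estimated at 11000 nM, within a range from 5000 nM to 25000 nM.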

Compound 3, half-maximal inhibitory concentration: 13000 nM
Beside the measured number, compound 3's estimate is 1.2-fold (0.07 log units) below it, within the range that was stated.
By their numbers in this assay, from the lowest: compounds 1, 3 and 2 (each within the scatter of the next).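

At the aromatic carbon ortho to a large group, iodo in place of isopropyl can now be read on a single change in this assay (a 1.1-fold lower number from compound 2 to compound 3 (0.03 log units; within the scatter)), and the number does not separate the two groups on this amide. The amide side also gains a single-change reading, methyl in place of hydrogen on a saturated chain carbon bound to a carbonyl carbon and a saturated chain carbon (a 1.2-fold higher number from compound 1 to compound 3 (0.07 log units; within the scatter)), and this too leaves the two compounds together. No measurement is available that bears on why these numbers stay together.

Still open, on these data alone, is whether an amine or a carboxylic acid at this aromatic carbon would give a step beyond the scatter. The same question stands for a longer chain on the amide.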